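Para Substituent Swap on a Diaryl Pyrazole Core

The source may hold more compounds than are shown below. What is called first, only, known or untested is meant among the compounds shown, and "the series" means these compounds.

Measured so far:
Compound 1 `O=[N+]([O-])c1ccc(-c2cc(-c3ccccc3)n[nH]2)cc1` gives 10200 nM in a functional assay on NCI-H460 cells (Homo sapiens) for inhibition, read by MTT assay, with a stated time of 48 h; on this read-out lower numbers stand for stronger inhibition of growth and higher numbers for weaker inhibition of growth.
Compound 2 `Nc1ccc(-c2cc(-c3ccccc3)n[nH]2)cc1` gives 26700 nM in this assay.

Going by the values given here, compound 2 stands highest of the two numbers; its nearest neighbour is compound 1, and the only measured step, a 2.6-fold higher number from compound 1 to compound 2 (0.42 log units; beyond the scatter), is the amino in place of nitro. Compound 3 `COc1ccc(-c2cc(-c3ccccc3)n[nH]2)cc1` differs from compound 2 by methoxy in place of amino on an aromatic carbon. Among the compounds with values here, no measured step covers a methoxy, so the one step bears on it only indirectly. A modest move downward, toward compound 1, is expected, a 1.8-fold lower number from compound 2 to compound 3 (0.25 log units; within the scatter). For compound 3 the estimate is 15000 nM, within 6000 nM to 40000 nM.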

Compound 3, concentration for 50% growth inhibition: 10400 nM
Compound 3: middle estimate off by 1.4-fold (0.16 log units), on the high side; the measured number falls inside the stated range.
By their numbers in this assay, from the lowest: compounds 1 and 3 (each within the scatter of the next); then compound 2.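

On this aromatic carbon, the amino group now stands apart from two other groups rather than one, with a 2.6-fold lower number from compound 2 to compound 3 (0.41 log units; beyond the scatter). Methoxy and nitro, which share no group type, cannot be told apart here, with a 1.0-fold higher number from compound 1 to compound 3 (0.01 log units; within the scatter), so the earlier amino in place of nitro step was not specific to nitro. Nothing measured on these compounds explains this result.

On these data alone, whether a chloro group, a carboxylic acid or a longer alkoxy chain on this carbon would read like methoxy and nitro or like amino stays open. So does whether the amino group stands apart on any other core.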